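Alpha-methylene lactones: trifluoromethyl on the pendant aryl ring

The source may report more compounds than this note shows. Statements on the series, on what has been measured and on what is new or still open speak of the compounds shown alone.

Measured so far:
compound 1, `C=C1C(=O)O[C@@H](c2ccccc2)[C@H]1C`, 114%;
compound 2, `C=C1C(=O)O[C@H](c2ccc3ccccc3c2)[C@H]1C`, 74%;
compound 3, `C=C1C(=O)O[C@H](c2ccccc2)[C@H]1c1ccccc1`, 30%.

All three were run in a functional assay on MIA PaCa-2 cells (Homo sapiens) for cytotoxicity, read by MTT assay, with a stated time of 72 h, tested at 1 uM; a higher number here means a weaker effect of the compound at the concentration tested, a lower number a stronger effect. Compound 3 gives the lowest number of the three; its separation from compound 2 and from compound 1 lies beyond the usual scatter, so compound 3 reads as the strongest of the measured set at this concentration.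

Compound 4 is `C=C1C(=O)O[C@H](c2ccc(C(F)(F)F)cc2)[C@H]1c1ccccc1`. Relative to compound 3 the change is trifluoromethyl in place of hydrogen on an aromatic carbon, on an aromatic carbon of a six-membered aromatic ring of carbon only. Among the measured compounds shown here, no measured pair shows this change, so there is no step to lean on. The expectation is a small step, a number 4 percentage points lower from compound 3 to compound 4 (within the scatter), not clearly beyond the scatter. Compound 4 is therefore estimated at 26%, within 10% to 45%.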

Compound 4, a percentage reported as activity, at one concentration (the size of the read-out at that concentration, not a potency): 142%
Compound 4: the middle estimate sits 116 percentage points below what was measured; the whole stated range lies below it.
By their numbers in this assay, from the lowest: compound 3; then compound 2; then compound 1; then compound 4.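

In this assay, trifluoromethyl in place of hydrogen on an aromatic carbon, para to a large group, gives a number 112 percentage points higher from compound 3 to compound 4 (beyond the scatter), a large step. This place on the ring is therefore not a silent one: a single change, with the rest of compound 3 untouched, removes the effect seen at the concentration tested. Nothing at hand bears on the reason for this loss.

As far as these compounds go, whether the loss belongs to trifluoromethyl alone or to any group at this place stays open. A single fluorine, a methoxy group or an amine there would separate the two readings.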